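Para substituent swap on the cinnamamide of compound 1

The source may report more compounds than this note shows. Statements on the series, on what has been measured and on what is new or still open speak of the compounds shown alone.

Measured compounds:
- compound 1, `O=C(/C=C/c1ccc([N+](=O)[O-])cc1)Nc1cc(-c2ccccc2)[nH]n1`: 720 nM
- compound 2, `Cc1ccc(-c2cc(NC(=O)/C=C/c3ccc(Cl)cc3)n[nH]2)cc1`: 1520 nM
- compound 3, `COc1ccc(/C=C/C(=O)Nc2cc(-c3ccc(C)cc3)[nH]n2)cc1`: 1370 nM

The three compounds share a cinnamamide attached to a pyrazole that carries an aryl group, and they were tested in a functional assay on B16-F10 cells (Mus musculus) for antiproliferative activity, read by MTT assay, with a stated time of 48 h; a lower number here means a stronger inhibitor, a higher number a weaker inhibitor. Compound 1 gives the lowest of the three numbers, though its gap to compound 3 lies within the scatter and only its gap to compound 2 lies beyond it. Compound 4, `Cc1ccc(/C=C/C(=O)Nc2cc(-c3ccccc3)[nH]n2)cc1`, has not yet been measured. It differs from compound 1 in one place: methyl in place of nitro on an aromatic carbon. For the measured compounds named here, the one measured step that bears on a change at this place is a 1.1-fold lower number from compound 2 to compound 3 (0.05 log units; within the scatter), which shows that exchanging one para group for another on the cinnamamide ring left the number essentially where it was. Compounds 2 and 3, however, carry a different aryl group on the pyrazole, so the bearing is indirect. The number for compound 4 is therefore expected to be close to that of compound 1, with a slight drift toward a higher number, a 1.5-fold higher number from compound 1 to compound 4 (0.18 log units; within the scatter). Compound 4 is estimated at 1100 nM, within a range from 450 nM to 2800 nM.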

Compound 4, half-maximal inhibitory concentration: 1680 nM
For compound 4 the middle estimate is 1.5-fold (0.18 log units) below the measured one; the measured number falls inside the stated range.
By their numbers in this assay, from the lowest: compounds 1, 3, 2 and 4 (each within the scatter of the next, the first and the last beyond it).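

In this assay the exchange of nitro for methyl on the aromatic carbon para to a large group gives a 2.3-fold higher number from compound 1 to compound 4 (0.37 log units; beyond the scatter), so this place on the core of compound 1 responds to a substituent swap by a modest but readable amount. The earlier step at the same place, a 1.1-fold lower number from compound 2 to compound 3 (0.05 log units; within the scatter), involved chloro and methoxy on a core with a different aryl group and showed no such shift, so a change here does not always leave the number where it was. Nothing measured in this set accounts for the difference between the two steps.

Going by these compounds, it remains open whether chloro or methoxy on the core of compound 1 would behave like nitro or like methyl. On these data alone, how an amine, a carboxylic acid or a nitrile at this place would compare also remains open.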